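Pendant aryl swap on the shared core

The source may report more compounds than this note shows. Statements on the series, on what has been measured and on what is new or still open speak of the compounds shown alone.

Three compounds share one core and differ only in the aryl group attached to it. Compound 1 `CCCS(=O)(=O)Nc1ccc(F)c(C(=O)c2n[nH]c3ncc(-c4ccccc4)cc23)c1F` carries plain phenyl and in an assay for binding affinity to dual specificity mitogen-activated protein kinase kinase 4 (Homo sapiens), read by KINOMEscan, tested at 100 nM (on this read-out higher numbers stand for a weaker effect at the one concentration tested and lower numbers for a stronger effect), compound 1 gives 2.4%. Compound 2 `CCCS(=O)(=O)Nc1ccc(F)c(C(=O)c2n[nH]c3ncc(-c4ccccc4F)cc23)c1F` carries 2-fluorophenyl and gives 2%. Compound 3 `CCCS(=O)(=O)Nc1ccc(F)c(C(=O)c2n[nH]c3ncc(-c4ccc(F)cc4)cc23)c1F` carries 4-fluorophenyl and gives 2.1%. The three numbers sit close together: the step of a number 0.4 percentage points lower from compound 1 to compound 2 (within the scatter) and the step of a number 0.3 percentage points lower from compound 1 to compound 3 (within the scatter) are both within the scatter, as is the step of a number 0.1 percentage points higher from compound 2 to compound 3 (within the scatter). Compound 3 thus stands second highest of three numbers, its nearest neighbour compound 2 and its furthest compound 1, both within the scatter, so no order among the three can be read.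

Compound 4 `CCCS(=O)(=O)Nc1ccc(F)c(C(=O)c2n[nH]c3ncc(-c4ccccc4OC)cc23)c1F` is the next member. It differs from compound 3 by 2-methoxyphenyl in place of 4-fluorophenyl on an aromatic carbon. The measured steps that bear on this change are the three aryl substituent swaps above, each within the scatter; none of them involves a methoxy group, so the evidence for compound 4 is indirect. Given that each swap so far left the read-out essentially unchanged, the expected step of a number 0.9 percentage points higher from compound 3 to compound 4 (within the scatter) is none beyond the scatter, with added uncertainty for the new substituent. Compound 4 is therefore estimated at 3%, within a range from 1% to 15%.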

Compound 4, a percentage reported as activity, at one concentration (the size of the read-out at that concentration, not a potency): 1.9%
Compound 4: the middle estimate sits 1.1 percentage points above what was measured; measured number inside the range.
By their numbers in this assay, from the lowest: compounds 4, 2, 3 and 1 (each within the scatter of the next).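

Working from 4-fluorophenyl, 2-methoxyphenyl brings a hydrogen-bond acceptor to this position, and in this assay the swap gives a number 0.2 percentage points lower from compound 3 to compound 4 (within the scatter). Within the 2-substituted aryl pair, methoxy in place of fluoro gives a number 0.1 percentage points lower from compound 2 to compound 4 (within the scatter), and against plain phenyl, methoxy in place of hydrogen gives a number 0.5 percentage points lower from compound 1 to compound 4 (within the scatter), so this oxygen-bearing substituent, the first at this position, leaves the read-out indistinguishable from those of the three earlier compounds. No order among the four can be read, and no supporting evidence bears on this result.

All four values lie close together at a single concentration, so the series does not yet show what kind of group on the pendant aryl, if any, would move the number beyond the scatter. As far as these compounds go, a dimethylaminomethyl group, a carboxylic acid or a longer chain such as butoxy in place of methoxy would test this, and how far this position stays open to such groups remains unanswered.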